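This account rests on a few compounds, and the source may have more. Where it says the series, first, only, none or still open, it means among the compounds named here.

For the measured compounds named here, compound 1 `CCCC(=O)Nc1ccc(Oc2cccc(OC)c2)cc1` carries the lowest of the two numbers so far in an assay on isolated protein for binding affinity to melatonin receptor type 1B (Homo sapiens); a higher number here means a weaker inhibitor, a lower number a stronger inhibitor: compound 1 gives 0.75 nM, while compound 2 `COc1cccc(Oc2ccc(NC(C)=O)cc2)c1` gives 4.1 nM. That step, a 5.5-fold higher number from compound 1 to compound 2 (0.74 log units; beyond the scatter), shows that hydrogen in place of ethyl on a saturated chain carbon bound to a carbonyl carbon weakens binding. Compound 3 `COCC(=O)Nc1ccc(Oc2cccc(OC)c2)cc1` alters the same place: methoxy in place of ethyl on a saturated chain carbon bound to a carbonyl carbon. Since methoxy keeps the chain at the same size as ethyl, the loss seen on cutting the chain to hydrogen is not expected to recur fully; a step of about a 2.0-fold higher number from compound 1 to compound 3 (0.30 log units; within the scatter) is expected, within or close to the scatter. Compound 3 is estimated at 1.5 nM (range 0.5 nM to 5 nM).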

Compound 3, inhibition constant: 5.9 nM
Compound 3: the middle estimate sits 3.9-fold (0.59 log units) below what was measured; measured number above the stated range.
By their numbers in this assay, from the lowest: compound 1; then compounds 2 and 3 (each within the scatter of the next).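

Equal heavy-atom count does not preserve binding at this position: in this assay the change from ethyl to methoxy gives a 7.9-fold higher number from compound 1 to compound 3 (0.90 log units; beyond the scatter) and so loses most of what ethyl gains over hydrogen. Against hydrogen at the same place, methoxy gives a 1.4-fold higher number from compound 2 to compound 3 (0.16 log units; within the scatter) and no separable change, so among these three compounds only ethyl gives the lower number. No measurement at hand accounts for the difference between ethyl and methoxy. Open, going by these compounds, is whether propyl or dimethylamino in place of ethyl would match or go beyond compound 1.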